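Dropping the methoxy from the biaryl tail: what to expect

The compounds below may be only part of what the source reports. "The series", "measured", "known", "first", "only" and "open" are said of these compounds alone.

Measured compounds:
compound 1 `COc1cc2c(Oc3ccc(NC(=O)c4cc(-c5ccc(C(F)(F)F)cc5)ccn4)cc3F)ccnc2cc1OCCCN1CCCCC1` gives 360 nM
compound 2 `COc1ccc(-c2ccnc(C(=O)Nc3ccc(Oc4ccnc5cc(OCCCN6CCCCC6)c(OC)cc45)c(F)c3)c2)cc1` gives 200 nM

For the measured compounds named here, in a functional assay on NCI-H460 cells (Homo sapiens) for cytotoxicity, read by MTT assay, with a stated time of 72 h (a higher number here means a weaker inhibitor, a lower number a stronger inhibitor), compound 2 stands at the lower of the two numbers, with compound 1 nearest; the one measured step, a 1.8-fold lower number from compound 1 to compound 2 (0.26 log units; within the scatter), is within the scatter. Compound 3 `COc1cc2c(Oc3ccc(NC(=O)c4cc(-c5ccccc5)ccn4)cc3F)ccnc2cc1OCCCN1CCCCC1` differs from compound 2 by hydrogen in place of methoxy on an aromatic carbon. Going by the values given here, only that single step bears on this change, and it was small, so a step of a 1.5-fold higher number from compound 2 to compound 3 (0.18 log units; within the scatter) is expected, not beyond the scatter. Compound 3 is estimated at 300 nM, within a range from 120 nM to 750 nM.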

Compound 3, half-maximal inhibitory concentration: 120 nM
Compound 3: middle estimate off by 2.5-fold (0.40 log units), on the high side; low and high end bracket the measured number.
By their numbers in this assay, from the lowest: compounds 3, 2 and 1 (each within the scatter of the next, the first and the last beyond it).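

In this assay, removing the substituent to leave a plain phenyl gives a 1.7-fold lower number from compound 2 to compound 3 (0.22 log units; within the scatter), so methoxy and hydrogen at this ring carbon cannot be told apart. Trifluoromethyl and hydrogen can be told apart, though only modestly, with a 3.0-fold lower number from compound 1 to compound 3 (0.48 log units; beyond the scatter). Nothing measured explains this difference.

As far as these compounds go, it remains open whether an amine or a carboxylic acid on this carbon would read like hydrogen or like trifluoromethyl. From the compounds shown here alone, whether a longer chain here would be tolerated is also open.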